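The source may report more compounds than this note shows. Statements on the series, on what has been measured and on what is new or still open speak of the compounds shown alone.

Compound 2, `COc1ccc(N(C)c2nc(C)nc3ccccc23)cc1C(=O)OCC[Se]C#N`, gives 2390 nM in a functional assay on RKO cells (Homo sapiens) for inhibition, read by MTT assay, with a stated time of 48 h (on this read-out higher numbers stand for weaker inhibition and lower numbers for stronger inhibition), the highest of the three numbers measured. Compound 1, `COc1ccc(N(C)c2nc(C)nc3ccccc23)cc1C(=O)OCCCCC[Se]C#N`, gives 356 nM, and compound 3, `CN(c1ccc([Se]C#N)cc1)c1nc(C2CC2)nc2ccccc12`, gives 51 nM; compound 2 thus sits a long way above both. Among the compounds with values here, the one single-point step among the measured compounds is a 6.7-fold higher number from compound 1 to compound 2 (0.83 log units; beyond the scatter), which shows that shortening the saturated chain that carries the selenocyanate weakens inhibition well beyond the scatter.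

Compound 4, `COc1ccc(N(C)c2nc(C)nc3ccccc23)cc1OCCC[Se]C#N`, is reached from compound 2 by a group of 7 heavy atoms (4 carbon, 1 nitrogen, 1 oxygen, 1 selenium; no ring) in place of a group of 8 heavy atoms (4 carbon, 1 nitrogen, 2 oxygen, 1 selenium; no ring), on an aromatic carbon. Here the ester linkage is gone and the selenocyanate hangs from an ether oxygen on the aromatic carbon, with the chain length between ring and selenium roughly preserved. Within the data shown here, the step from compound 1 to compound 2 bears on this only indirectly, since it concerns chain length rather than the nature of the link; no measured pair shows an ester exchanged for an ether. With the chain kept short, a number in the same region as compound 2 is expected, with a slight lean toward stronger inhibition given that compound 1 at 356 nM shows the series can reach lower numbers. Compound 4 is therefore estimated at 1200 nM, between 350 nM and 4500 nM, an expected step of a 2.0-fold lower number from compound 2 to compound 4 (0.30 log units; within the scatter).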

Compound 4, half-maximal inhibitory concentration: 799 nM
Compound 4: the middle estimate sits 1.5-fold (0.18 log units) above what was measured, within the range that was stated.
By their numbers in this assay, from the lowest: compound 3; then compound 1; then compound 4; then compound 2.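

In this assay the group on the aromatic carbon ortho to a methoxy group can be exchanged without loss of inhibition, with a 3.0-fold lower number from compound 2 to compound 4 (0.48 log units; beyond the scatter) as the ether-linked selenocyanate enters and the ester-linked group leaves. The earlier compounds shown here varied only the saturated chain within the ester, whereas this step shows that the carbonyl is not needed for inhibition on these cells, since the entering group has no double bond outside the aromatic rings and still gives the lower number. The swap alters the link and the chain together, so the step cannot be assigned to either one alone, and nothing available here gives a reason for the lower number.

The compounds shown leave open whether a longer chain on the ether oxygen would lower the number further, as the longer chain did in the ester pair, where the shortening gave a 6.7-fold higher number from compound 1 to compound 2 (0.83 log units; beyond the scatter). They also leave open how an amide link at the same aromatic carbon, or an ester and an ether of identical chain length, would compare.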